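A few compounds are considered here, and "the series" means these few. Any claim that something is new, unique, unknown or untested is made for them only; others in the source may bear on it.

Compound 1 `COC(=O)Nc1cc(-c2ccc(OC[C@@](C)(N)CC(C)C)c(C)c2)ccn1` is the reference point here. In an assay on isolated protein for inhibition of AP2-associated protein kinase 1 (Homo sapiens), with a stated time of 3 h, in the presence of a further agent that is not named here (on this read-out lower numbers stand for stronger inhibition and higher numbers for weaker inhibition), compound 1 gives 0.8 nM, the lowest of the three numbers recorded. Compound 3 `COC(=O)Nc1cc(-c2ccc(OC[C@@](C)(N)CC(C)C)c(F)c2)ccn1` carries a fluorine where compound 1 carries a methyl. Compound 3 gives 1.1 nM; the step of a 1.4-fold higher number from compound 1 to compound 3 (0.14 log units; within the scatter) lies within the usual scatter, so the two compounds cannot be ranked against each other. Compound 2 `COC(=O)Nc1cc(-c2ccc(OC[C@@](C)(N)CC(C)C)cn2)ccn1`, in which a ring carbon of the outer ring has become a nitrogen, gives 23 nM, and its gap to compound 1 is well beyond the scatter.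

Compound 4 `COC(=O)Nc1cc(-c2ccc(OC[C@@](C)(N)CC(C)C)c(C)c2C)ccn1` is not yet measured. It differs from compound 1 by methyl in place of hydrogen on an aromatic carbon; the new methyl sits on an aromatic carbon of a six-membered aromatic ring of carbon only, ortho to a large group, ortho to a methyl group and meta to the (2-amino-2,4-dimethylpentyl)oxy group. Going by the values given here, the only measured step that touches this ring's substituent, from compound 1 to compound 3, was within the scatter. Among the compounds with values here, no measured step adds a second small group to this ring, so the expectation rests on that single comparison. The step is expected to be a 1.9-fold higher number from compound 1 to compound 4 (0.27 log units; within the scatter). Compound 4 is therefore estimated at 1.5 nM, in a range from 0.5 nM to 5 nM.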

Compound 4, half-maximal inhibitory concentration: 4.5 nM
The estimate for compound 4 lay 3.0-fold (0.48 log units) below the measured number, within the range that was stated.
By their numbers in this assay, from the lowest: compounds 1 and 3 (each within the scatter of the next); then compound 4; then compound 2.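

In this assay, placing a methyl on this ring carbon, ortho to a large group and ortho to a methyl group, gives a 5.6-fold higher number from compound 1 to compound 4 (0.75 log units; beyond the scatter). Going by these compounds alone, until now the only change on this ring that kept the outer ring all carbon was the swap of methyl for fluoro, a 1.4-fold higher number from compound 1 to compound 3 (0.14 log units; within the scatter), which sat at another carbon and could not be told apart from repeat-to-repeat variation, so this is the first sign that a carbon of this ring can respond to a small addition, even though the number stays in the low nanomolar range. No measurement is available here that would explain the rise.

The compounds shown carry only hydrogen or methyl at this carbon, so how a fluorine, a methoxy group or an amine there would read remains open. Also open, on these data alone, is whether the higher number belongs to this carbon alone or to its pairing with the methyl group already present, which the new methyl combined with a fluorine or a hydrogen in place of that group could help to separate.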